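Compound 4: tert-butoxy in place of 2-carboxyethyl

The source may hold more compounds than are shown below. What is called first, only, known or untested is meant among the compounds shown, and "the series" means these compounds.

In a functional assay on MCF7 cells (Homo sapiens) for antiproliferative activity, read by luminescence, with a stated time of 24 h (a lower number here means a stronger inhibitor, a higher number a weaker inhibitor), compound 1 `Cc1cc(C)c2c(c1C)OC(C)(COc1ccc(/C=C3\SC(=O)NC3=O)cc1)CC2` gives 12500 nM and compound 2 `Cc1c(C)c2c(c(C)c1O)CCC(C)(COc1ccc(/C=C3\SC(=O)NC3=O)cc1)O2` gives 29700 nM. Compound 3 `Cc1c(C)c2c(c(C)c1OC(=O)CCC(=O)O)CCC(C)(COc1ccc(/C=C3\SC(=O)NC3=O)cc1)O2` gives > 50000 nM, which is a limit of the assay and not a number.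

Compound 4 `Cc1c(C)c2c(c(C)c1OC(=O)OC(C)(C)C)CCC(C)(COc1ccc(/C=C3\SC(=O)NC3=O)cc1)O2` differs from compound 3 by tert-butoxy in place of 2-carboxyethyl on a carbonyl carbon, with tert-butoxy in place of 2-carboxyethyl on a carbonyl carbon.

Within the data shown here, three measured steps bear on this change: a 2.4-fold higher number from compound 1 to compound 2 (0.38 log units; beyond the scatter), an at least 4.0-fold higher number from compound 1 to compound 3 (0.60 log units; beyond the scatter) and an at least 1.6-fold higher number from compound 2 to compound 3 (0.22 log units; that floor lies within the scatter). None of them tests tert-butoxy directly, so the expectation is only a modest move toward the value of compound 2, 29700 nM.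

The expected step is an at least 2.5-fold lower number from compound 3 to compound 4 (0.39 log units; beyond the scatter).

The estimate for compound 4 is 20000 nM, with an expected range of 7000 nM to 50000 nM.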

Compound 4, half-maximal inhibitory concentration: 7700 nM
The estimate for compound 4 lay 2.6-fold (0.41 log units) above the measured number; low and high end bracket the measured number.
By their numbers in this assay, from the lowest: compounds 4 and 1 (each within the scatter of the next); then compound 2. At a limit, above all of these: compound 3.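

In this assay, tert-butoxycarbonyl in place of hydrogen on the aromatic ring's oxygen gives a 3.9-fold lower number from compound 2 to compound 4 (0.59 log units; beyond the scatter), so substitution on this oxygen need not raise the number, which compound 3 alone could not show. Tert-butoxy in place of 2-carboxyethyl on the carbonyl carbon gives an at least 6.4-fold lower number from compound 3 to compound 4 (0.81 log units; beyond the scatter), a floor only, as compound 3 stands at a limit of the assay: the limit of > 50000 nM in this assay, at which 1 of the 4 values shown sits. Set against hydrogen on the aromatic carbon, (tert-butoxycarbonyl)oxy gives a 1.6-fold lower number from compound 1 to compound 4 (0.21 log units; within the scatter), so the two are not separated.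

Still open, going by these compounds, is how a shorter alkoxy such as methoxy, or an amine, would behave on this carbonyl carbon. Whether a longer chain ending in a carboxylic acid stays at the limit also remains unsettled.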